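Cytotoxicity at the Assay Limit: from Compound 2 to Compound 3

A few compounds are considered here, and "the series" means these few. Any claim that something is new, unique, unknown or untested is made for them only; others in the source may bear on it.

Measured compounds:
compound 1 `COc1cccc(-c2csc(NC(=O)c3ccc([N+](=O)[O-])cc3)n2)c1`: > 90000 nM
compound 2 `CCOc1cccc(-c2csc(NC(=O)c3ccc([N+](=O)[O-])o3)n2)c1`: > 90000 nM

In an ADME assay on Vero cells (Chlorocebus sabaeus) for cytotoxicity, read by MTT assay, with a stated time of 72 h (a higher number here means a weaker inhibitor, a lower number a stronger inhibitor), compound 1 gives only a limit, > 90000 nM. In this assay compound 2 also gives only a limit, > 90000 nM. Both values rest at the limit of > 90000 nM in this assay, at which 2 of the 2 values shown sit, so nothing separates them. Compound 3 `O=C(Nc1nc(-c2cccc(NC(=O)C3CCCCC3)c2)cs1)c1ccc([N+](=O)[O-])o1` differs from compound 2 by (cyclohexylcarbonyl)amino in place of ethoxy on an aromatic carbon. For the measured compounds named here, no measured step exists for this change, so the expected step is none beyond the scatter, a number no higher from compound 2 to compound 3 (the limit leaves the size open). Compound 3 is expected to give 90000 nM, with a range from 30000 nM to 200000 nM, most likely again only a limit.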

Compound 3, half-maximal inhibitory concentration in the Vero assay: 21900 nM
Compound 3: middle estimate off by 4.1-fold (0.61 log units), on the high side, outside the stated range (below it).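

In the Vero assay, putting (cyclohexylcarbonyl)amino in place of ethoxy on this aromatic carbon gives an at least 4.1-fold lower number from compound 2 to compound 3 (0.61 log units; beyond the scatter), so this position can move the read-out, which the earlier compounds could not show: the limit of > 90000 nM in the Vero assay, at which 2 of the 3 values shown sit. The same change also gives a higher number in a physicochemical assay for solubility, read by HPLC, with a stated time of 30 min (on this read-out higher numbers stand for higher solubility and lower numbers for lower solubility), where compound 2 gives 0.34 ug/mL and compound 3 gives 3.46 ug/mL: the measured solubility of compound 2, 0.34 ug/mL, and of compound 3, 3.46 ug/mL, a 10-fold higher number (1.01 log units; beyond the scatter)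

The compounds shown leave open whether the cyclohexyl ring or the amide link carries these steps. An amine or a longer alkoxy chain on this aromatic carbon could help separate the two.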